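The source may report more compounds than this note shows. Statements on the series, on what has been measured and on what is new or still open speak of the compounds shown alone.

Three compounds have been measured in an assay on isolated protein for binding affinity to corticotropin-releasing factor receptor 1 (Homo sapiens); on this read-out higher numbers stand for weaker inhibition and lower numbers for stronger inhibition:
compound 1 `CC(=O)/C(=N\c1cccc(C)c1)NNc1ccccc1C`, 526 nM
compound 2 `CC(=O)/C(=N\c1cccc(F)c1)NNc1ccccc1C`, 43 nM
compound 3 `CC(=O)/C(=N\c1cccc(C(F)(F)F)c1)NNc1ccccc1C`, 291 nM

Compound 2 stands lowest of the three numbers in this assay; the steps of a 12-fold lower number from compound 1 to compound 2 (1.09 log units; beyond the scatter) and a 6.8-fold higher number from compound 2 to compound 3 (0.83 log units; beyond the scatter) both lie beyond the scatter, so it is the strongest binder of the three.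

Compound 4 `CC(=O)/C(=N\c1cccc(F)c1)NNc1ccccc1C(F)(F)F` differs from compound 2 by trifluoromethyl in place of methyl on an aromatic carbon. The measured step that bears most on this is a 1.8-fold lower number from compound 1 to compound 3 (0.26 log units; within the scatter), the same exchange of methyl for trifluoromethyl on the other ring, which stayed within the scatter. The step of a 6.8-fold higher number from compound 2 to compound 3 (0.83 log units; beyond the scatter) compares trifluoromethyl with fluoro rather than with methyl, and also on the other ring, so it bears less directly. The step expected here, a 1.3-fold higher number from compound 2 to compound 4 (0.11 log units; within the scatter), is therefore small, with no clear direction beyond the scatter. In this assay compound 4 is expected to give 55 nM, between 20 nM and 160 nM.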

Compound 4, inhibition constant: 197 nM
For compound 4 the middle estimate is 3.6-fold (0.55 log units) below the measured one; the whole stated range lies below it.
By their numbers in this assay, from the lowest: compound 2; then compounds 4, 3 and 1 (each within the scatter of the next, the first and the last beyond it).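

On this ring, ortho to a large group, trifluoromethyl in place of methyl weakens binding, with a 4.6-fold higher number from compound 2 to compound 4 (0.66 log units; beyond the scatter). The earlier compounds had shown this exchange only on the other ring, where it made no clear difference, so its outcome cannot be carried from one core to the other: the same change on two cores in this assay, a 1.8-fold lower number (0.26 log units; within the scatter) from compound 1 to compound 3 and a 4.6-fold higher number (0.66 log units; beyond the scatter) from compound 2 to compound 4, 8.3-fold (0.92 log units) apart, beyond the scatter of two such steps

The compounds shown hold only methyl and trifluoromethyl at this position, so it remains open how fluoro, an amine or a longer chain would fare there. Also open, as far as these compounds go, is whether any group there would bind more strongly than methyl.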